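The source may report more compounds than this note shows. Statements on the series, on what has been measured and on what is new or still open speak of the compounds shown alone.

Working notes on the series

Three members of the series have numbers in a functional assay (aorta) for antagonist activity, with Oryctolagus cuniculus as the target; on this read-out higher numbers stand for weaker inhibition and lower numbers for stronger inhibition. Compound 1 `CCCCc1ccc(CN(Cc2ccccc2)S(=O)(=O)c2ccc(C)cc2)c(=O)n1Cc1ccc(-c2ccccc2-c2nn[nH]n2)cc1` gives 60 nM. Compound 2 `CCCCc1ccc(CN(Cc2ccccc2)S(=O)(=O)c2ccccc2)c(=O)n1Cc1ccc(-c2ccccc2-c2nn[nH]n2)cc1` gives 20 nM. Compound 3 `CCCCc1cccc(=O)n1Cc1ccc(-c2ccccc2-c2nn[nH]n2)cc1` gives 4 nM, the lowest of the three numbers, with compound 2 nearest and compound 1 furthest. Compound 4 `CCCCc1ccc(C)c(=O)n1Cc1ccc(-c2ccccc2-c2nn[nH]n2)cc1` is still to be measured in this assay.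

One measured pair already shows a methyl added to an aromatic carbon: methyl in place of hydrogen on an aromatic carbon, which produced a 3.0-fold higher number from compound 2 to compound 1 (0.48 log units; beyond the scatter). Compound 4 differs from compound 3 by methyl in place of hydrogen on an aromatic carbon. This is the same kind of change, not the same: in compound 1 the methyl enters on a six-membered aromatic ring of carbon only, para to a large group, whereas in compound 4 it enters on a six-membered aromatic ring with 1 nitrogen, ortho to a group of 1 heavy atom, two atoms from the ring nitrogen, meta to a large group and para to a butyl group. How the core of compound 3 differs from the core of compound 2 is not broken down here.

For compound 4 a modest rise in the number is expected in this assay, because the one measured case of this kind of change gave a 3.0-fold higher number from compound 2 to compound 1 (0.48 log units; beyond the scatter); with the place so different, the expected step is somewhat smaller, a 2.0-fold higher number from compound 3 to compound 4 (0.30 log units; within the scatter). Compound 4 is therefore estimated at 8 nM, expected to fall between 3 nM and 25 nM.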

Compound 4, half-maximal inhibitory concentration: 7 nM
Beside the measured number, compound 4's estimate is 1.1-fold (0.06 log units) above it; low and high end bracket the measured number.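

The methyl in place of hydrogen on an aromatic carbon gives, in this assay, a 1.8-fold higher number from compound 3 to compound 4 (0.24 log units; within the scatter), so on this core the step cannot be told apart from repeat measurement. On the other core the same change gave a 3.0-fold higher number from compound 2 to compound 1 (0.48 log units; beyond the scatter), and the two steps point the same way and do not differ in size beyond what two such steps can show: the same change on two cores in this assay, a 3.0-fold higher number (0.48 log units; beyond the scatter) from compound 2 to compound 1 and a 1.8-fold higher number (0.24 log units; within the scatter) from compound 3 to compound 4, 1.7-fold (0.23 log units) apart, within the scatter of two such steps

This agreement supports carrying the methyl step from one core to the other as a first estimate in this series, but two pairs establish no rule, and the step is read as real on only one of them. The methyl also enters on a six-membered aromatic ring of carbon only in compound 1 and on a six-membered aromatic ring with 1 nitrogen in compound 4, so the compounds shown cannot separate the effect of the core from the effect of the place.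

Open, from the compounds shown here alone, is whether an ethyl, a hydroxymethyl or a carboxylic acid on the same aromatic carbon of compound 3 would give a step beyond the scatter. Also open, going by these compounds, is whether the methyl step keeps its size when a longer chain stands in place of the butyl group.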